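A few compounds are considered here, and "the series" means these few. Any claim that something is new, unique, unknown or untested is made for them only; others in the source may bear on it.

Measured compounds and their values:

compound 1, `CCOC(=O)[C@@H](N)CCC(=O)NCCSC(C)=O`: 1730000 nM
compound 2, `CCCCOC(=O)[C@@H](N)CCC(=O)NCCSC(=O)c1ccccc1`: 97000 nM
compound 3, `CCCOC(=O)[C@@H](N)CCC(=O)NCCSC(=O)c1ccccc1`: 75000 nM

These three compounds were tested in an ADME assay on HaCaT cells (Homo sapiens) for cytotoxicity, read by MTT assay, with a stated time of 48 h; a higher number here means that more compound is needed for the effect, a lower number that less compound is needed. Compound 1 stands highest of the three in this assay, so it needs the most compound for the effect; compound 2 and compound 3 sit well below it, beyond the scatter. Compound 2 and compound 3 differ only in the ester chain, and the step of a 1.3-fold lower number from compound 2 to compound 3 (0.11 log units; within the scatter) lies within the scatter, so that change in the ester chain shows no effect here.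

Compound 4, `CCOC(=O)[C@@H](N)CCC(=O)NCCSC(=O)C(C)(C)C`, has not yet been measured in this assay. It differs from compound 1 in one place: tert-butyl in place of methyl on a carbonyl carbon

Within the data shown here, no measured step touches this position. Compound 2 and compound 3 carry a larger group on the same carbonyl carbon than compound 1 does, and both give lower numbers, but they also differ from compound 1 in the ester chain, so their values cannot be read as a step for this change alone. The direction they suggest is a lower number, and a moderate fall is expected for compound 4, a 2.5-fold lower number from compound 1 to compound 4 (0.39 log units; beyond the scatter), with a wide range given the absence of a direct comparison. The estimate for compound 4 in this assay is 700000 nM, between 250000 nM and 1900000 nM.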

Compound 4, half-maximal effective concentration: 228000 nM
The estimate for compound 4 lay 3.1-fold (0.49 log units) above the measured number; the whole stated range lies above it.
By their numbers in this assay, from the lowest: compounds 3 and 2 (each within the scatter of the next); then compound 4; then compound 1.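

Among these compounds, until now this carbonyl carbon had no step of its own, as compound 2 and compound 3 also differ from compound 1 in the ester chain. In this assay, tert-butyl in place of methyl on a carbonyl carbon whose other neighbour is sulfur gives a 7.6-fold lower number from compound 1 to compound 4 (0.88 log units; beyond the scatter), with the rest of the molecule unchanged. This shows that a change at this position alone, with no change in the ester chain, moves the number beyond the usual scatter and means less compound is needed for the effect, although nothing available here bears on why this happens.

As far as these compounds go, a single pair cannot show how the number follows the size of the group, so it remains open whether ethyl or isopropyl on the same carbonyl carbon would give part of this step or none of it. From the compounds shown here alone, it is also open whether tert-butyl would give a similar step on the propyl and butyl ester chains of compound 3 and compound 2, and whether a group carrying an amine or a carboxylic acid at this position would move the number the same way.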